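The source may report more compounds than this note shows. Statements on the series, on what has been measured and on what is new or still open speak of the compounds shown alone.

Of the compounds shown here, two have been tested so far in an assay on isolated protein for agonist activity at prostaglandin E2 receptor EP2 subtype (Homo sapiens); a lower number here means that less compound is needed, a higher number that more compound is needed for the effect. Compound 1 `CCCCC1([C@H](O)/C=C/[C@H]2COC(=O)N2CCSc2nc(C(=O)O)cs2)CCC1` gives 2.9 nM in this assay. Compound 2 `CC(C)(CCCCF)[C@H](O)/C=C/[C@H]1COC(=O)N1CCSc1nc(C(=O)O)cs1` gives 5.7 nM in this assay. These two numbers are not separated: a 2.0-fold higher number from compound 1 to compound 2 (0.29 log units; within the scatter), so compound 1 stands level with compound 2 rather than apart from it.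

Compound 3 `CC#CCC1([C@H](O)/C=C/[C@H]2COC(=O)N2CCSc2nc(C(=O)O)cs2)CCC1` has not yet been measured. It differs from compound 1 in a single place: prop-1-yn-1-yl in place of propyl on a saturated chain carbon bound to a saturated ring carbon. Within the data shown here, the only measured step, that from compound 1 to compound 2, also alters the side chain on the same saturated chain carbon of the shared core, and it stayed within the scatter. On that basis compound 3 is expected to sit close to compound 1, with a step of a 1.4-fold higher number from compound 1 to compound 3 (0.14 log units; within the scatter) in this assay. The estimate for compound 3 in this assay is therefore 4 nM, expected to fall between 1.5 nM and 12 nM.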

Compound 3, half-maximal effective concentration: 21 nM
Estimate against measurement, compound 3: 5.3-fold (0.72 log units) below, outside the stated range (above it).
By their numbers in this assay, from the lowest: compounds 1 and 2 (each within the scatter of the next); then compound 3.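

In this assay, replacing propyl with prop-1-yn-1-yl leaves the count of 3 heavy atoms unchanged yet gives a 7.2-fold higher number from compound 1 to compound 3 (0.86 log units; beyond the scatter), so this side chain responds even when the main difference is a triple bond. Compound 2, with its 5-fluoro-1,1-dimethylpentyl group, also separates from the alkyne, with a 3.7-fold higher number from compound 2 to compound 3 (0.57 log units; beyond the scatter), whereas the two side chains without a triple bond, in compound 1 and compound 2, stand level within the scatter. Nothing measured here gives a reason for this rise.

Going by these compounds, it remains open where a but-2-en-1-yl chain, with a double bond in place of the triple bond of compound 3, would fall in this assay. Also open, on these data alone, is whether a triple bond would have a similar effect on the side chain of compound 2.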